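Extending the benzylic ring in a quinazoline amine series

This account rests on a few compounds, and the source may have more. Where it says the series, first, only, none or still open, it means among the compounds named here.

Compound 1 `FC(F)(F)c1ccccc1-c1nc(NCc2ccc(Cl)c(Cl)c2)c2ccccc2n1` gives 10400 nM in an assay on a protein complex for inhibition of ubiquitin carboxyl-terminal hydrolase 1/WD repeat-containing protein 48 (Homo sapiens), read by fluorescence; on this read-out lower numbers stand for stronger inhibition and higher numbers for weaker inhibition.
Compound 2 `N#Cc1ccc(CNc2nc(-c3ccccc3C(F)(F)F)nc3ccccc23)cc1` gives 5700 nM in this assay.
Compound 3 `FC(F)(F)c1ccccc1-c1nc(NCC#Cc2cccnc2)c2ccccc2n1` gives 8900 nM in this assay.

Compound 2 carries the nitrile on the ring attached to the saturated chain carbon, and its number sits closest to compound 3 a 1.6-fold higher number from compound 2 to compound 3 (0.19 log units; within the scatter) and furthest from compound 1 a 1.8-fold lower number from compound 1 to compound 2 (0.26 log units; within the scatter); all three values lie within the scatter of one another. Compound 4 `FC(F)(F)c1cc(-c2ccc(CNc3nc(-c4ccccc4C(F)(F)F)nc4ccccc34)cc2)ccn1` changes that position: 2-(trifluoromethyl)pyridin-4-yl in place of cyano on an aromatic carbon. The steps from the measured pairs all swap groups at this same place and none moved the number beyond the scatter, yet none added a second aromatic ring, so no close guide exists. Compound 4 is therefore expected to give 3500 nM, with a range from 900 nM to 14000 nM, corresponding to an estimated step of a 1.6-fold lower number from compound 2 to compound 4 (0.21 log units; within the scatter).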

Compound 4, half-maximal inhibitory concentration: 4900 nM
Beside the measured number, compound 4's estimate is 1.4-fold (0.15 log units) below it, and the stated range covers the measured number.
By their numbers in this assay, from the lowest: compounds 4, 2, 3 and 1 (each within the scatter of the next, the first and the last beyond it).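

The earlier steps shown here exchanged the whole group on the saturated chain carbon, whereas here a second aromatic ring enters on an aromatic carbon in place of cyano. The number barely registers this much larger group (a 1.2-fold lower number from compound 2 to compound 4 (0.07 log units; within the scatter)), so this position accepts 2-(trifluoromethyl)pyridin-4-yl without a shift beyond the scatter. No measurement at hand explains this tolerance. Open, from the compounds shown here alone, is whether an amine or a carboxylic acid on this aromatic carbon would move the number beyond the scatter. Also open, going by these compounds, is whether plain pyridin-4-yl, lacking the trifluoromethyl group, would read the same.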